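The source may hold more compounds than are shown below. What is called first, only, known or untested is meant among the compounds shown, and "the series" means these compounds.

Compound 1 `O=C(/C=C/c1ccc2c(c1)B(O)OC2)c1ccc(Br)cc1` in a functional assay on SK-OV-3 cells (Homo sapiens) for cytotoxicity, read by MTT assay, with a stated time of 48 h (a lower number here means a stronger inhibitor, a higher number a weaker inhibitor), gives 4500 nM. Among the three measured compounds it stands second highest: compound 2 `CCc1ccc(C(=O)/C=C/c2ccc3c(c2)B(O)OC3)cc1`, which in this assay gives 4400 nM, lies nearest at a 1.0-fold lower number from compound 1 to compound 2 (0.01 log units; within the scatter), while compound 3 `CCOC(=O)c1ccc(C(=O)/C=C/c2ccc3c(c2)B(O)OC3)cc1`, which in this assay gives 7100 nM, lies furthest at a 1.6-fold higher number from compound 1 to compound 3 (0.20 log units; within the scatter). Both of those steps, like a 1.6-fold higher number from compound 2 to compound 3 (0.21 log units; within the scatter), fall within the scatter.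

Compound 4 `O=C(/C=C/c1ccc2c(c1)B(O)OC2)c1cccc(O)c1` differs from compound 1 by 3-hydroxyphenyl in place of 4-bromophenyl on a carbonyl carbon. The measured steps all exchange a group on an aromatic carbon, and none of them moves the number in this assay beyond the scatter, so a change of the whole ring to 3-hydroxyphenyl is expected to leave the number much where it is. Among the compounds with values here, none of the measured steps brings in a hydrogen-bond donor, so this expectation rests only on the absence of movement seen so far. Compound 4 is therefore expected to give 5000 nM, within a range from 2000 nM to 12000 nM, a step of a 1.1-fold higher number from compound 1 to compound 4 (0.05 log units; within the scatter) that is not expected to exceed the scatter.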

Compound 4, half-maximal inhibitory concentration: 3800 nM
For compound 4 the middle estimate is 1.3-fold (0.12 log units) above the measured one, and the stated range covers the measured number.
By their numbers in this assay, from the lowest: compounds 4, 2, 1 and 3 (each within the scatter of the next).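

Exchanging the whole ring on the carbonyl carbon, with 3-hydroxyphenyl bringing in a hydrogen-bond donor and a hydrogen-bond acceptor that 4-bromophenyl lacks, gives a 1.2-fold lower number from compound 1 to compound 4 (0.07 log units; within the scatter) in this assay. Within the data shown here, the earlier steps only exchanged a group on an aromatic carbon, so this is the first sign that a hydrogen-bond donor can enter here without moving the number beyond the scatter. No measurement among the data bears on why the number stays where it does.

The compounds shown leave open whether an amine or a carboxylic acid on this ring would move the number beyond the scatter. They also leave open what 4-hydroxyphenyl or 3-bromophenyl would give, so the place of the group on the ring cannot be told apart from the exchange of bromo for hydroxy.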